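The source may report more compounds than this note shows. Statements on the series, on what has been measured and on what is new or still open speak of the compounds shown alone.

Working notes on the series.

Compound 1 `C/C(=C\Cc1c(CCC(=O)c2ccc(O)cc2O)ccc(O)c1O)CCCC(C)(C)O` and compound 2 `COC(C)(C)CCC/C(C)=C/Cc1c(CCC(=O)c2ccc(O)cc2O)ccc(O)c1O` share an open-chain core; compound 3 `CC(C)(O)CCCC1(C)CCc2c(CCC(=O)c3ccc(O)cc3O)ccc(O)c2O1` and compound 4 `COC(C)(C)CCCC1(C)CCc2c(CCC(=O)c3ccc(O)cc3O)ccc(O)c2O1` share a second core, and the difference between the two cores is not broken down here. In a functional assay on PANC-1 cells (Homo sapiens) for cytotoxicity, read by fluorescence, with a stated time of 24 h (on this read-out lower numbers stand for stronger inhibition and higher numbers for weaker inhibition), compound 1 gives only a limit, > 75000 nM. In this assay compound 2 likewise gives only a limit, > 75000 nM. In this assay compound 3 gives 36700 nM. The change from compound 1 to compound 2 methyl in place of hydrogen on an oxygen on a saturated carbon is the same change as from compound 3 to compound 4 (methyl in place of hydrogen on an oxygen on a saturated carbon); its measured step is a step that the two limits leave unreadable from compound 1 to compound 2, which is unreadable because of the limit of > 75000 nM in this assay, at which 2 of the 3 values shown sit. With no readable precedent, the step is expected to be small, a 1.2-fold higher number from compound 3 to compound 4 (0.09 log units; within the scatter), resting on compound 3 at 36700 nM as the anchor. Compound 4 is estimated at 45000 nM.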

Compound 4, half-maximal inhibitory concentration: 48300 nM
Beside the measured number, compound 4's estimate is 1.1-fold (0.03 log units) below it; the measured number falls inside the stated range.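

In this assay hydroxy to methoxy on the core of compound 3 reads as a 1.3-fold higher number from compound 3 to compound 4 (0.12 log units; within the scatter) and so stays within the usual scatter of repeated measurements on this core. This is one readable case of the change, so it shows no measurable effect on this core and does not show that the result carries from one core to the other. The same change on the open-chain core of compound 1 cannot be read, because both values there are limits: the limit of > 75000 nM in this assay, at which 2 of the 4 values shown sit.

On these data alone, whether an ethoxy group, a longer chain on that oxygen, or an amine or carboxylic acid in place of the hydroxy would read differently stays open. Also open, as far as these compounds go, is how either core would respond to such groups.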